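A few compounds are considered here, and "the series" means these few. Any claim that something is new, unique, unknown or untested is made for them only; others in the source may bear on it.

Measured compounds in an assay for inhibition of RAC-alpha serine/threonine-protein kinase (Homo sapiens), read by HTRF, with a stated time of 1 h; on this read-out lower numbers stand for stronger inhibition and higher numbers for weaker inhibition:
Compound 1 `Cn1ncc(Cl)c1-c1cc(C(=O)N[C@@H]2CNCC[C@H]2c2ccc(C(F)(F)F)cc2)oc1Cl` gives 9.3 nM.
Compound 2 `Cn1ncc(Cl)c1-c1cc(C(=O)N[C@@H]2CN[C@H](CCn3cncn3)C[C@H]2c2ccc(Cl)c(Cl)c2)oc1Cl` gives 4.47 nM.
Compound 3 `Cn1ncc(Cl)c1-c1cc(C(=O)N[C@H]2CNCC[C@@H]2c2ccc(C(F)(F)F)cc2)oc1Cl` gives 127 nM.

Among these three, compound 2 gives the lowest number in this assay, with compound 1 nearest to it and compound 3 furthest away; its steps to both lie beyond the scatter, so it is the most potent of the measured set. Within the data shown here, the only step between compounds that differ in one place is a 14-fold higher number from compound 1 to compound 3 (1.14 log units; beyond the scatter), a large one, which rests on (the fact that compounds 1 and 3 differ only in the configuration as drawn).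

Compound 4 `COCC[C@@H]1C[C@@H](c2ccc(Cl)c(Cl)c2)[C@H](NC(=O)c2cc(-c3c(Cl)cnn3C)c(Cl)o2)CN1` has not yet been measured in this assay. It differs from compound 2 by methoxy in place of 1H-1,2,4-triazol-1-yl on a saturated chain carbon, two bonds along the chain from a saturated ring carbon. Among the measured compounds shown here, no measured step touches this part of the molecule: the known step between compound 1 and compound 3 concerns configuration alone and says nothing about a substituent on a saturated chain carbon two bonds along the chain from a saturated ring carbon. Compound 2 is therefore the only anchor, and the data give no direction for the exchange of 1H-1,2,4-triazol-1-yl for methoxy. The expected step is a 1.3-fold higher number from compound 2 to compound 4 (0.13 log units; within the scatter), likely within the scatter. Compound 4 is estimated at 6 nM, expected to fall between 2.5 nM and 15 nM.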

Compound 4, half-maximal inhibitory concentration: 7.01 nM
Compound 4: the middle estimate sits 1.2-fold (0.07 log units) below what was measured, within the range that was stated.
By their numbers in this assay, from the lowest: compounds 2, 4 and 1 (each within the scatter of the next, the first and the last beyond it); then compound 3.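

Read in this assay, the exchange of 1H-1,2,4-triazol-1-yl for methoxy on a saturated chain carbon, two bonds along the chain from a saturated ring carbon, is a step within the scatter (a 1.6-fold higher number from compound 2 to compound 4 (0.20 log units; within the scatter)). Among these compounds, it is the first reading at this position, and it shows that the five-membered aromatic ring is not needed there for a low number, since methoxy, with no ring, serves as well. Nothing at hand bears on why the two groups read alike.

The compounds shown leave open whether an amine, a carboxylic acid or a longer chain in place of methoxy would also stay within the scatter. They also leave open how the 2-methoxyethyl group would read on the core of compound 1.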